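Swapping chloro for carboxymethyl on the amide side chain

The source may hold more compounds than are shown below. What is called first, only, known or untested is meant among the compounds shown, and "the series" means these compounds.

Within the data shown here, compound 2 `O=C(CCl)Nc1ccc(-c2nc3cc(C(F)(F)F)ccc3[nH]2)cc1` gives 5000 nM in an ADME assay on MT4 cells (Homo sapiens) for cytotoxicity, read by MTT assay, with a stated time of 96 h (on this read-out higher numbers stand for lower toxicity in this test and lower numbers for higher toxicity in this test), the lower of two numbers, with compound 1 `Fc1ccc(-c2nc3cc(C(F)(F)F)ccc3[nH]2)cc1` at 22000 nM as its only neighbour; that pair gave a 4.4-fold lower number from compound 1 to compound 2 (0.64 log units; beyond the scatter). Compound 3 `O=C(O)CCC(=O)Nc1ccc(-c2nc3cc(C(F)(F)F)ccc3[nH]2)cc1` differs from compound 2 by carboxymethyl in place of chloro on a saturated chain carbon bound to a carbonyl carbon. Among the measured compounds shown here, no measured step covers this exchange, and the single step from compound 1 to compound 2 touches the same side chain only loosely. Compound 3 is therefore expected to move back toward the upper number, by roughly a 3.6-fold higher number from compound 2 to compound 3 (0.56 log units; beyond the scatter). Compound 3 is estimated at 18000 nM, within 6000 nM to 55000 nM.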

Compound 3, half-maximal cytotoxic concentration: > 100000 nM
Compound 3 ended at the assay's limit; the forecaster's own chance of this, stated with the estimate: 30%; at least 5.5-fold (0.74 log units) between middle value and limit.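

In this assay, carboxymethyl in place of chloro on a saturated chain carbon bound to a carbonyl carbon gives an at least 20-fold higher number from compound 2 to compound 3 (1.30 log units; beyond the scatter) and so reverses the fall seen with the chloromethyl side chain. The same side chain also ends on the far side of the fluoro starting point, with an at least 4.5-fold higher number from compound 1 to compound 3 (0.65 log units; beyond the scatter) as the step. The value of compound 3 is a limit of the assay and not a number: the limit of > 100000 nM in this assay, at which 1 of the 3 values shown sits.

The compounds shown leave open whether the carboxylic acid or the longer chain accounts for this change. A methyl ester or a plain propyl chain in place of 2-carboxyethyl would separate the two.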